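Trimming a Hydroxypiperidine Side Chain in an Antiproliferative Series

The source may hold more compounds than are shown below. What is called first, only, known or untested is meant among the compounds shown, and "the series" means these compounds.

Of the compounds shown here, three sharing one core have been measured in a functional assay on OVCAR-8 cells (Homo sapiens) for antiproliferative activity; a higher number here means a weaker inhibitor, a lower number a stronger inhibitor. Compound 1 `Cn1ncc(Cl)c1-c1cc(C(=O)N[C@@H]2CN[C@H](CC(=O)O)C[C@H]2c2ccc(Cl)c(Cl)c2)oc1Cl` gives 5120 nM in this assay. Compound 2 `CC(=O)OCC[C@@H]1C[C@@H](c2ccc(F)c(F)c2)[C@H](NC(=O)c2cc(-c3c(Cl)cnn3C)c(Cl)o2)CN1` gives 4960 nM. Going by the values given here, compound 3 `Cn1ncc(Cl)c1-c1cc(C(=O)N[C@@H]2CN[C@H](CCN3CCC(O)CC3)C[C@H]2c2ccc(Cl)c(Cl)c2)oc1Cl` gives 15900 nM, the highest of the three numbers; its nearest neighbour is compound 1, and the step of a 3.1-fold higher number from compound 1 to compound 3 (0.49 log units; beyond the scatter) is the only single-place change among the measured compounds. Compound 2 differs from compound 3 in more than one place, so its value serves only as a second point that lies close to compound 1.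

Compound 4 `COCC[C@@H]1C[C@@H](c2ccc(Cl)c(Cl)c2)[C@H](NC(=O)c2cc(-c3c(Cl)cnn3C)c(Cl)o2)CN1` has not yet been measured. Relative to compound 3, the change is methoxy in place of 4-hydroxypiperidin-1-yl on a saturated chain carbon, two bonds along the chain from a saturated ring carbon. Among the compounds with values here, the one step that bears on it runs in the opposite sense: attaching the 4-hydroxypiperidin-1-yl group to the chain of compound 1 raised the number, and compound 4 now removes that group, leaving a methoxy on the chain. Compounds 1 and 2, which carry neither group, sit close together. A modest step back toward those two values is therefore expected, with a 2.9-fold lower number from compound 3 to compound 4 (0.46 log units; beyond the scatter) as the anticipated size. Compound 4 is estimated at 5500 nM in this assay, within a range from 2500 nM to 13000 nM.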

Compound 4, half-maximal inhibitory concentration: 1060 nM
Estimate against measurement, compound 4: 5.2-fold (0.72 log units) above; the whole stated range lies above it.
By their numbers in this assay, from the lowest: compound 4; then compounds 2 and 1 (each within the scatter of the next); then compound 3.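

Going by these compounds alone, the result shows that the side chain can lower the number as well as raise it: in this assay, the only earlier step at this place was a 3.1-fold higher number from compound 1 to compound 3 (0.49 log units; beyond the scatter), whereas methoxy in place of 4-hydroxypiperidin-1-yl, on a saturated chain carbon two bonds along the chain from a saturated ring carbon, gives a 15-fold lower number from compound 3 to compound 4 (1.18 log units; beyond the scatter), a large step. Compound 4 also separates from the carboxy-bearing compound, with methoxymethyl in place of carboxy giving a 4.8-fold lower number from compound 1 to compound 4 (0.68 log units; beyond the scatter), so the value of compound 1 was not a level that the series returns to once the 4-hydroxypiperidin-1-yl group has gone, and the three compounds that differ only in this side chain now stand apart, each beyond the scatter of the others. No measurement accompanying these compounds accounts for either step.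

The compounds shown leave open whether a simple hydroxy or an ethoxy at the end of this chain would match compound 4 at 1060 nM in this assay. They also leave open whether a small dimethylamino group would behave like the 4-hydroxypiperidin-1-yl group, and whether a longer chain ending in methoxy would hold the gain.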